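The source may hold more compounds than are shown below. What is called first, only, known or untested is meant among the compounds shown, and "the series" means these compounds.

In a functional assay on DU-145 cells (Homo sapiens) for cytotoxicity, read by MTT assay, with a stated time of 48 h (a higher number here means a weaker inhibitor, a lower number a stronger inhibitor), compound 1 (`COc1ccc(-c2nc3ccccn3c2C(=O)/C=C\Nc2cnc3ccccc3c2)cc1`) gives 5280 nM and compound 2 (`O=C(/C=C\Nc1ccc2cc[nH]c2c1)c1c(-c2ccc(Cl)cc2)nc2ccccn12`) gives 2630 nM and so the two sit within the usual scatter of each other. Compound 3 (`O=C(/C=C\Nc1cnc2ccccc2c1)c1c(-c2ccc(Cl)cc2)nc2ccccn12`) keeps the rest of compound 2 but carries quinolin-3-yl in place of 1H-indol-6-yl on an amine nitrogen. Among the measured compounds shown here, no measured pair shows this swap on its own, so the expectation rests on compound 1 at 5280 nM and compound 2 at 2630 nM as the only guides. The expected step is a 1.3-fold higher number from compound 2 to compound 3 (0.12 log units; within the scatter) and it stays within the scatter. Compound 3 is estimated at 3500 nM with an expected range of 1300 nM to 9000 nM (an estimate, not a measurement).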

Compound 3, half-maximal inhibitory concentration: 4170 nM
Compound 3: the middle estimate sits 1.2-fold (0.08 log units) below what was measured; the measured number falls inside the stated range.
By their numbers in this assay, from the lowest: compounds 2, 3 and 1 (each within the scatter of the next).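

In this assay, quinolin-3-yl in place of 1H-indol-6-yl on the amine nitrogen gives a 1.6-fold higher number from compound 2 to compound 3 (0.20 log units; within the scatter) even though the hydrogen-bond donor of 1H-indol-6-yl leaves and quinolin-3-yl brings a hydrogen-bond acceptor. Chloro in place of methoxy on an aromatic carbon gives a 1.3-fold lower number from compound 1 to compound 3 (0.10 log units; within the scatter) and so also does not separate the compounds. Nothing measured here explains why either step is this small. Going by these compounds, whether a plain phenyl ring or a longer chain ending in a carboxylic acid on that amine nitrogen would move the number beyond the scatter stays open.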